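This account rests on a few compounds, and the source may have more. Where it says the series, first, only, none or still open, it means among the compounds named here.

Measured so far:
compound 1, `C=CC(C)(C)c1[nH]c2ccc(C[C@@H](Cl)C(C)(C)O)cc2c1/C=C1\NC(=O)[C@H](C)NC1=O`: 97000 nM
compound 2, `C=CC(C)(C)c1[nH]c2c(C[C@@H](O)C(C)(C)Cl)cccc2c1/C=C1\NC(=O)[C@H](C)NC1=O`: 77000 nM

In a functional assay (on this read-out lower numbers stand for stronger inhibition and higher numbers for weaker inhibition), compound 1 gives 97000 nM, and compound 2 gives 77000 nM; the two values lie within the scatter of each other, so neither compound can be set apart from the other on the numbers shown. Compound 2 thus stands level with compound 1, and both sit far up the concentration scale in this assay.

Compound 3, `C=CC(C)(C)c1[nH]c2c(CC=C(C)C)cccc2c1/C=C1\NC(=O)[C@H](C)NC1=O`, is not yet measured. It differs from compound 2 in one place: 2-methylprop-1-en-1-yl in place of 2-chloro-1-hydroxy-2-methylpropyl on a saturated chain carbon bound to an aromatic carbon. Within the data shown here, no step between measured compounds bears on this change, so there is nothing to set its size or direction from. With both measured values weak and no guide, the step from compound 2 to compound 3 is expected to be small, no more than the scatter, in either direction: a 1.3-fold lower number from compound 2 to compound 3 (0.11 log units; within the scatter). Compound 3 is therefore estimated at 60000 nM in this assay, with a range from 15000 nM to 250000 nM.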

Compound 3, half-maximal inhibitory concentration: 86000 nM
The estimate for compound 3 lay 1.4-fold (0.16 log units) below the measured number; low and high end bracket the measured number.
By their numbers in this assay, from the lowest: compounds 2, 3 and 1 (each within the scatter of the next).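

In this assay, 2-methylprop-1-en-1-yl in place of 2-chloro-1-hydroxy-2-methylpropyl on a saturated chain carbon bound to an aromatic carbon gives a 1.1-fold higher number from compound 2 to compound 3 (0.05 log units; within the scatter) and so lies within the scatter. At this place the chain can therefore lose its chlorine, its hydroxy group and its defined stereocentre without a difference this read-out can resolve, and compound 3 remains far up the concentration scale with compound 2. No supporting measurement accounts for this flat step.

From the compounds shown here alone, whether any group at this place can bring the number down remains open, since the two groups compared here give no direction. A terminal amine, a carboxylic acid or a longer chain in the same place would test whether this position responds at all.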